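The compounds below may be only part of what the source reports. "The series", "measured", "known", "first", "only" and "open" are said of these compounds alone.

Working notes on the series, read in a functional assay on U-87MG ATCC cells for antiproliferative activity against U-87 MG (Homo sapiens), read by spectrophotometry, with a stated time of 2 days; a lower number here means a stronger inhibitor of growth, a higher number a weaker inhibitor of growth. Going by the values given here, compound 3 `Cc1cc(Cl)ccc1Nc1ncc(C(F)(F)F)c(N2Cc3cccc(N(C)S(C)(=O)=O)c3C2)n1` gives 28300 nM, the higher of the two actual numbers so far. Compound 2 `COc1cc(Nc2ncc(C(F)(F)F)c(N3Cc4cccc(N(C)S(C)(=O)=O)c4C3)n2)c(OC)cc1Cl` gives 6200 nM. Compound 1 `Cc1ccc(Nc2ncc(C(F)(F)F)c(N3Cc4cccc(N(C)S(C)(=O)=O)c4C3)n2)c(Cl)c1` gives > 30000 nM, which is a limit of the assay and not a number.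

Next in line is compound 4 `CN(c1cccc2c1CN(c1nc(Nc3cccc(C(F)(F)F)c3)ncc1C(F)(F)F)C2)S(C)(=O)=O`. The change is 3-(trifluoromethyl)phenyl in place of 4-chloro-2-methylphenyl on a nitrogen on an aromatic ring, with 3-(trifluoromethyl)phenyl in place of 4-chloro-2-methylphenyl on a nitrogen on an aromatic ring. Among the compounds with values here, three measured steps bear on it, since all of them exchange the group at that same place. The first runs an at least 1.0-fold lower number from compound 1 to compound 3 (0.02 log units; that floor lies within the scatter), and its floor lies within the scatter. The other two are modest and both involve the 4-chloro-2,5-dimethoxyphenyl group of compound 2: an at least 4.8-fold lower number from compound 1 to compound 2 (0.68 log units; beyond the scatter) and a 4.6-fold higher number from compound 2 to compound 3 (0.66 log units; beyond the scatter). Only that group has moved the number beyond the scatter among these three compounds, and compound 4 does not carry it. Compound 4 is therefore expected to stay close to compound 3 in this assay, with no step beyond the scatter. The expected change is a 1.3-fold lower number from compound 3 to compound 4 (0.11 log units; within the scatter). For compound 4 the estimated value is 22000 nM, with an expected range of 8000 nM to 40000 nM.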

Compound 4, concentration for 50% growth inhibition: > 30000 nM
Compound 4 gave a limit, no number (the forecaster's own chance of this, stated with the estimate: 35%); middle value at least 1.3-fold (0.13 log units) from the limit.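

With 3-(trifluoromethyl)phenyl on the nitrogen, a group carrying neither chlorine nor methyl joins the series, and this assay gives an at least 1.0-fold higher number from compound 3 to compound 4 (0.02 log units; that floor lies within the scatter), so this exchange shows no difference that can be read beyond the scatter. The comparison with the dimethoxy-bearing group gives an at least 4.8-fold higher number from compound 2 to compound 4 (0.68 log units; beyond the scatter), and compound 2, at 6200 nM, now has steps beyond the scatter to all three other compounds, which makes it the strongest of the four here. Compound 1 and compound 4 each stand at a limit of the assay and not at a number, so the step between them cannot be read, and three different aryl groups have now failed to move clear of that ceiling, with the limit itself recurring: the limit of > 30000 nM in this assay, at which 2 of the 4 values shown sit.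

Still open is which part of the 4-chloro-2,5-dimethoxyphenyl group carries the lower number, as the compounds shown do not separate its two methoxy groups from each other or from its chlorine. Also open, from the compounds shown here alone, is whether a morpholine, a primary amine or a carboxylic acid on this phenyl ring would bring the number below that of compound 2.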